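Removing one amide arm: what solubility to expect

The source may hold more compounds than are shown below. What is called first, only, known or untested is meant among the compounds shown, and "the series" means these compounds.

Compound 1 `CNC(=O)c1cc(C(=O)NC2CCC2)cn(Cc2cccc(NC)c2)c1=O`: in a physicochemical assay for solubility (on this read-out lower numbers stand for lower solubility and higher numbers for higher solubility), compound 1 reaches only an assay limit, >= 155 ug/mL.
Compound 2 `CNC(=O)c1cc(C(=O)NC2CCC2)cn(Cc2ccccc2)c1=O`: compound 2 gives 28 ug/mL.
Compound 3 `CNC(=O)c1cc(C(=O)NC2CCC2)cn(Cc2cccnc2)c1=O`: compound 3 also reaches only an assay limit, >= 99 ug/mL.

Going by the values given here, compound 2 is therefore the single plain number among the three; the other two values are limits. Compound 4 `CNC(=O)c1cccn(Cc2ccccc2)c1=O` differs from compound 2 by hydrogen in place of cyclobutylcarbamoyl on an aromatic carbon. Among the compounds with values here, none of the measured steps touches this position: the steps of an at least 5.5-fold lower number from compound 1 to compound 2 (0.74 log units; beyond the scatter) and an at least 3.5-fold higher number from compound 2 to compound 3 (0.54 log units; beyond the scatter) both alter the group on the benzyl ring, and the step that the two limits leave unreadable from compound 1 to compound 3 cannot be read. The data thus fix neither size nor direction for the new change. Compound 4 is expected to give 60 ug/mL, within 20 ug/mL to 200 ug/mL. The expected step of a 2.1-fold higher number from compound 2 to compound 4 (0.33 log units; beyond the scatter) is only a guess of modest size.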

Compound 4, solubility: 78 ug/mL
Compound 4: the middle estimate sits 1.3-fold (0.11 log units) below what was measured; low and high end bracket the measured number.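

Replacing cyclobutylcarbamoyl with hydrogen gives a 2.8-fold higher number from compound 2 to compound 4 (0.44 log units; beyond the scatter) in this assay. Going by these compounds alone, the earlier steps all changed the benzyl end, so this is the first reading for this position on the shared core. It shows that a group of this size can leave this aromatic carbon without the number falling.

On these data alone, what an amine or a carboxylic acid at this position would give stays open, as does whether the same step would hold with the other benzyl-end groups. No measurement shown gives a reason for the step.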